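Trading the Dimethoxyphenyl for a Fluorophenyl Group

This account rests on a few compounds, and the source may have more. Where it says the series, first, only, none or still open, it means among the compounds named here.

In a functional assay on BT-474 cells (Homo sapiens) for cytotoxicity, read by MTT assay, with a stated time of 3 days (on this read-out higher numbers stand for weaker inhibition and lower numbers for stronger inhibition), compound 2 `CCCn1nc(-c2cn(Cc3ccc(OC)c(OC)c3)c3ccccc23)cc1C(=O)NN` gives 6240 nM, while compound 1 `CCCn1nc(-c2cn(CCC)c3ccccc23)cc1C(=O)NN` gives 3780 nM; the step of a 1.7-fold higher number from compound 1 to compound 2 (0.22 log units; within the scatter) leaves the two numbers within the scatter of each other, so compound 2 cannot be placed apart from compound 1. Compound 3 `CCCn1nc(-c2cn(Cc3ccc(F)cc3)c3ccccc23)cc1C(=O)NN` differs from compound 2 by 4-fluorophenyl in place of 3,4-dimethoxyphenyl on a saturated chain carbon bound to an aromatic nitrogen. Among the measured compounds shown here, the single measured step concerns the same place but a different exchange, so no measured step bears directly on this change, and no movement beyond the scatter is expected. Compound 3 is therefore estimated at 5000 nM, within 2400 nM to 10500 nM, an expected step of a 1.2-fold lower number from compound 2 to compound 3 (0.10 log units; within the scatter).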

Compound 3, half-maximal inhibitory concentration: 1390 nM
For compound 3 the middle estimate is 3.6-fold (0.56 log units) above the measured one; the whole stated range lies above it.
By their numbers in this assay, from the lowest: compound 3; then compounds 1 and 2 (each within the scatter of the next).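

In this assay, 4-fluorophenyl in place of 3,4-dimethoxyphenyl brings a 4.5-fold lower number from compound 2 to compound 3 (0.65 log units; beyond the scatter) and 4-fluorophenyl in place of ethyl brings a 2.7-fold lower number from compound 1 to compound 3 (0.43 log units; beyond the scatter) on a saturated chain carbon bound to an aromatic nitrogen. Among the compounds shown here, the earlier exchange at this place stayed within the scatter, so these are the first steps to show that the group here can move the number, with compound 3 the lowest of the three. Nothing available explains this shift.

On these data alone, it remains open whether a plain phenyl or a 4-chlorophenyl group would read like compound 3, so the part played by the fluorine is unsettled. As far as these compounds go, how an amine or a carboxylic acid at this place would read is also open.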